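The compounds below may be only part of what the source reports. "The series", "measured", "known", "first", "only" and "open" are said of these compounds alone.

Compound 1 `COc1cc2oc(-c3cccc(NC(=O)c4ccc(Cl)cc4)c3)cc(=O)c2c(OC)c1OC` — 51.1%
Compound 2 `COc1cc2oc(-c3cccc(NC(=O)c4ccc(Br)cc4)c3)cc(=O)c2c(OC)c1OC` — 63.6%

In a functional assay on RXF 393 cells (Homo sapiens) for inhibition, read by sulforhodamine B assay, tested at 10 uM (on this read-out higher numbers stand for more inhibition at the one concentration tested (going by the name of the read-out) and lower numbers for less inhibition), compound 2 stands highest of the two measured compounds; its nearest neighbour is compound 1, which lies lower by the step of a number 12.5 percentage points higher from compound 1 to compound 2 (beyond the scatter). Compound 3 `COc1cc2oc(-c3cccc(C(=O)Nc4ccc(C)cc4)c3)cc(=O)c2c(OC)c1OC` differs from compound 2 by (4-methylphenyl)carbamoyl in place of ((4-bromophenyl)carbonyl)amino on an aromatic carbon. Among the compounds with values here, the one measured step concerns only the exchange of a halogen and does not bear on this change. Within the data shown here, with no step that covers it, compound 3 is expected to remain near the two measured compounds, and its estimate is 50% with a range of 25% to 75%, meaning an expected step of a number 13.6 percentage points lower from compound 2 to compound 3 (beyond the scatter).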

Compound 3, a percentage reported as inhibition, at one concentration (the size of the read-out at that concentration, not a potency): "active" (no number reported)
Nothing numeric was reported for compound 3, and the estimate cannot be compared.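

Within the data shown here, compound 3 is reported only as active, without a number, so no step from compound 2 can be read, and no other data bear on this result. The compounds shown leave open whether (4-methylphenyl)carbamoyl gives more or less inhibition than ((4-bromophenyl)carbonyl)amino.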